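Aryl amide exchange on a dodecylamide threonine scaffold

This account rests on a few compounds, and the source may have more. Where it says the series, first, only, none or still open, it means among the compounds named here.

Among the measured compounds shown here, compound 2 `CCCCCCCCCCCCNC(=O)[C@@H](NC(=O)c1nccc2ccccc12)[C@@H](C)O` is the only member with a number in a functional assay on HepG2 cells (Homo sapiens) for cytotoxicity, read by MTT assay, with a stated time of 48 h (a lower number here means a stronger inhibitor, a higher number a weaker inhibitor), where compound 2 gives 65700 nM. Compound 1 `CCCCCCCCCCCCNC(=O)[C@@H](NC(=O)c1ccccc1)[C@@H](C)O` gives only a limit of the assay, > 400000 nM. For the measured compounds named here, the step of an at least 6.0-fold lower number from compound 1 to compound 2 (0.78 log units; beyond the scatter) is the sole measured step, and its full size is hidden by the limit of > 400000 nM in this assay, at which 1 of the 2 values shown sits. Going by the values given here, compound 3 `CCCCCCCCCCCCNC(=O)[C@@H](NC(=O)c1cc2ccccc2[nH]1)[C@@H](C)O` differs by 1H-indol-2-yl in place of isoquinolin-1-yl on a carbonyl carbon, so a bicyclic aromatic group stays on the carbonyl carbon; no measured step tests this swap directly. A step within the scatter is expected, a 1.2-fold higher number from compound 2 to compound 3 (0.09 log units; within the scatter). Compound 3 is estimated at 80000 nM, with a range of 25000 nM to 300000 nM.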

Compound 3, half-maximal inhibitory concentration: 12000 nM
For compound 3 the middle estimate is 6.7-fold (0.82 log units) above the measured one; the measured number lies below the stated range.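

Bicyclic aromatic groups on this carbonyl carbon are not interchangeable in this assay: the step of a 5.5-fold lower number from compound 2 to compound 3 (0.74 log units; beyond the scatter) is beyond the scatter, with a hydrogen-bond donor entering and a hydrogen-bond acceptor leaving. The step of an at least 33-fold lower number from compound 1 to compound 3 (1.52 log units; beyond the scatter) gives only a minimum size, because compound 1 stands at a limit of the assay: the limit of > 400000 nM in this assay, at which 1 of the 3 values shown sits.

The compounds shown leave open whether the indole hydrogen-bond donor or the five-membered ring accompanies the lower number; a benzofuran-2-yl group on the same carbonyl carbon would separate the two. As far as these compounds go, how a shorter chain in place of dodecyl would read also remains open.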